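The compounds below may be only part of what the source reports. "The series", "measured", "known", "first", "only" and "open" are said of these compounds alone.

Compound 1, `COc1cc(/C=C/S(=O)(=O)Cc2ccc(OC)c([N+](=O)[O-])c2)cc(OC)c1`, gives 16500 nM in a functional assay on MDA-MB-468 cells (Homo sapiens) for cytotoxicity, read by MTT assay, with a stated time of 72 h; a higher number here means a weaker inhibitor of growth, a lower number a stronger inhibitor of growth. Going by the values given here, that is the only number recorded here. Compound 2, `COc1ccc(OC)c(NC(=O)CS(=O)(=O)Cc2ccc(OC)c([N+](=O)[O-])c2)c1`, gives only a limit of this assay, > 30000 nM, so the limit of > 30000 nM in this assay, at which 1 of the 2 values shown sits, marks where one of the two values sits. Compound 3, `COc1cc(/C=C/S(=O)(=O)Cc2ccc(OC)c(N)c2)cc(OC)c1`, differs from compound 1 by amino in place of nitro on an aromatic carbon. No measured step of this kind exists among the compounds shown, so the expectation rests on compound 1 alone. A step from compound 1 to compound 3 of a 1.2-fold higher number from compound 1 to compound 3 (0.08 log units; within the scatter) is expected, not beyond the scatter. Compound 3 is therefore estimated at 20000 nM, between 6000 nM and 60000 nM.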

Compound 3, concentration for 50% growth inhibition: 520 nM
Estimate against measurement, compound 3: 38-fold (1.59 log units) above, and the stated range ends above it.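

In this assay, amino in place of nitro on this aromatic carbon, ortho to a methoxy group, gives a 32-fold lower number from compound 1 to compound 3 (1.50 log units; beyond the scatter) and so is a large step beyond the scatter. The earlier compounds shown here held no step at this position, so only now is it clear that the group here can change the number strongly. Nothing shown here bears on the cause of this step. Going by these compounds, whether a hydroxyl, an acetamide or a dimethylamino group at this position would match the amino group stays open. So does whether the same change would carry over to the core of compound 2.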